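Methyl for Fluoro: A Step That Cannot Yet Be Read

A few compounds are considered here, and "the series" means these few. Any claim that something is new, unique, unknown or untested is made for them only; others in the source may bear on it.

Of the compounds shown here, three built on one shared core have been tested in an in vitro functional assay on HEK293-A cells for antagonist activity at metabotropic glutamate receptor 5 (Rattus norvegicus), read by calcium flux; a lower number here means a stronger inhibitor, a higher number a weaker inhibitor. Compound 1 `N#Cc1cc(F)cc(C(=O)Nc2ccccc2F)c1` carries a fluoro group on the outer ring; in this assay compound 1 reaches only the limit of the measurement, > 30000 nM. Compound 2 `N#Cc1cc(F)cc(C(=O)Nc2ccc(F)cc2)c1` has the same atoms joined differently, and the difference between the two cores is not broken down here; in this assay compound 2 again gives only a limit, > 10000 nM. Compound 3 `Cc1ccccc1NC(=O)c1cc(F)cc(C#N)c1` differs from compound 1 by methyl in place of fluoro on an aromatic carbon, and in this assay compound 3 also stops at a limit, > 30000 nM. The resulting step that the two limits leave unreadable from compound 1 to compound 3 therefore cannot be sized, because the limit of > 30000 nM in this assay, at which 2 of the 3 values shown sit, holds both of its ends.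

Compound 4 `Cc1ccc(NC(=O)c2cc(F)cc(C#N)c2)cc1` differs from compound 2 by methyl in place of fluoro on an aromatic carbon. This is the same kind of change as that from compound 1 to compound 3, but not the same: there the methyl stood ortho to a large group, here it stands para to a large group. Within the data shown here, no measured step of this kind is readable, and every value so far is a limit, as the limit of > 10000 nM in this assay, at which 1 of the 3 values shown sits, and the limit of > 30000 nM in this assay, at which 2 of the 3 values shown sit, show. The step from compound 2 to compound 4 is accordingly expected to be small, a step that the limit leaves unreadable from compound 2 to compound 4, resting on the observation that compound 3 stays at a limit after the like change. Compound 4 is estimated at 40000 nM, with a range from 8000 nM to 200000 nM.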

Compound 4, half-maximal inhibitory concentration: > 30000 nM
Compound 4 was reported as a limit; the forecaster's own chance of this, stated with the estimate: 85%; the middle value lies beyond the limit too.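

In this assay compound 4 gives > 30000 nM, which is a limit and not a number. Compound 2 is also held at a limit, so the step from compound 2 to compound 4 cannot be read. The four compounds shown leave open whether methyl in place of fluoro on an aromatic carbon changes inhibition at all in this assay, and what number any of them would give.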